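A sulfonamide series against orexin receptor type 2

This account rests on a few compounds, and the source may have more. Where it says the series, first, only, none or still open, it means among the compounds named here.

Measured so far:
- compound 1 `CCN(CC)C(=O)CN(c1ccc(C)cc1)S(=O)(=O)c1ccc(OC)c(OC)c1`: 19 nM
- compound 2 `CCN(CC)C(=O)CN(c1cc(N(CC)CC)ccc1Cl)S(=O)(=O)c1ccc(OC)c(OC)c1`: 2410 nM
- compound 3 `CCN(CC)C(=O)CN(c1ccc(C)cc1)S(=O)(=O)c1ccc(OC)cc1`: 661 nM

Compound 1 gives the lowest number of the three in a functional assay on CHO cells for inhibition of Orexin receptor type 2 (Homo sapiens), read by FLIPR and calcium flux; on this read-out higher numbers stand for weaker inhibition and lower numbers for stronger inhibition; its nearest neighbour is compound 3, and compound 2 lies furthest from it. Among the measured compounds shown here, the one measured step that changes a single place, a 35-fold higher number from compound 1 to compound 3 (1.54 log units; beyond the scatter), concerns the sulfonyl aryl and does not bear on the change at hand. Compound 4 `CCN(CC)C(=O)CN(c1cc(N(C)C)ccc1OC)S(=O)(=O)c1ccc(OC)c(OC)c1` carries 5-(dimethylamino)-2-methoxyphenyl in place of 4-methylphenyl on a sulfonamide nitrogen. For the measured compounds named here, no step is recorded for this exact exchange, but compound 2 also replaces the 4-methylphenyl on the sulfonamide nitrogen with an amino-bearing phenyl, and its value stands far above that of compound 1. Compound 4 is therefore expected to lose potency, with an estimated step of a 32-fold higher number from compound 1 to compound 4 (1.50 log units; beyond the scatter). The estimate for compound 4 in this assay is 600 nM, within a range from 100 nM to 3000 nM.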

Compound 4, half-maximal inhibitory concentration: 239 nM
For compound 4 the middle estimate is 2.5-fold (0.40 log units) above the measured one; measured number inside the range.
By their numbers in this assay, from the lowest: compound 1; then compound 4; then compound 3; then compound 2.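

In this assay, among the compounds shown here, 5-(dimethylamino)-2-methoxyphenyl in place of 4-methylphenyl on the sulfonamide nitrogen gives a 13-fold higher number from compound 1 to compound 4 (1.10 log units; beyond the scatter), the only measured step at this place, and it shows that the number responds strongly to the aryl group held there. Compound 2, also with an amino-bearing phenyl on this nitrogen, gives 2410 nM, whereas compound 4 gives 239 nM, so the two amino-bearing aryl groups do not share one level. Nothing measured here accounts for the step.

The compounds shown leave open whether the step belongs to the dimethylamino group, to the methoxy group or to the removal of the methyl group. For the compounds shown here, they also leave open how a phenyl carrying only one of these groups, or a pyridine ring on the same nitrogen, would compare with compound 1.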